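The source may hold more compounds than are shown below. What is called first, only, known or untested is meant among the compounds shown, and "the series" means these compounds.

Measured so far in a functional assay on HBL-100 cells (Homo sapiens) for inhibition, read by sulforhodamine B assay, with a stated time of 48 h; a lower number here means a stronger inhibitor of growth, a higher number a weaker inhibitor of growth:
- compound 1, `CCC(/C=C(\COC(C)=O)C(=O)c1ccccc1)CC`: > 100000 nM
- compound 2, `CC(=O)OC/C(=C\c1ccc(F)cc1)C(=O)c1ccccc1`: 17000 nM

The value for compound 1 is a limit of the assay rather than a number. Going by the values given here, compound 2 therefore carries the only actual number among the two measured compounds. Among the compounds with values here, the one measured step, an at least 5.8-fold lower number from compound 1 to compound 2 (0.76 log units; beyond the scatter), swaps an aliphatic group for a fluorinated aromatic ring and is at least modest in size.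

Compound 3, `CC(=O)OC/C(=C\c1ccccc1F)C(=O)c1ccccc1`, differs from compound 2 only in where the fluorine sits on the ring: 2-fluorophenyl in place of 4-fluorophenyl on a double-bonded chain carbon bound to a double-bonded chain carbon. Within the data shown here, no measured step here moves a substituent around an aromatic ring, and the step of an at least 5.8-fold lower number from compound 1 to compound 2 (0.76 log units; beyond the scatter) compares different group types, so it does not tell how this rearrangement will behave. Compound 3 is therefore expected to land close to compound 2, with an estimated step of no change at the digits printed from compound 2 to compound 3 (within the scatter) within the usual scatter. Compound 3 is estimated at 17000 nM, with a range from 6000 nM to 50000 nM.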

Compound 3, concentration for 50% growth inhibition: 17000 nM
Beside the measured number, compound 3's estimate shows no gap at the digits printed; the measured number falls inside the stated range.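

In this assay, moving the fluorine from 4-fluorophenyl to 2-fluorophenyl gives no change at the digits printed from compound 2 to compound 3 (within the scatter), so these two placements of the fluorine cannot be told apart in this assay. Putting 2-fluorophenyl in place of pentan-3-yl gives an at least 5.8-fold lower number from compound 1 to compound 3 (0.76 log units; beyond the scatter), which shows that the lower number seen with 4-fluorophenyl is repeated by a second fluorophenyl group. The full size of that step stays unknown because compound 1 stands at a limit of the assay rather than at a number: the limit of > 100000 nM in this assay, at which 1 of the 3 values shown sits.

From the compounds shown here alone, whether the ring needs a fluorine at all remains open, as a plain phenyl, a chlorophenyl or a methoxyphenyl group could read differently. Also open, going by these compounds, is how much the acetate ester of the shared core matters, for instance with an amine or a carboxylic acid in its place.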